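Ethylsulfanyl for methoxy on the pyridine of compound 2

The compounds below may be only part of what the source reports. "The series", "measured", "known", "first", "only" and "open" are said of these compounds alone.

Measured compounds:
compound 1, `COc1cc(N2CCCNCC2)cnc1Cl`, 0.676 nM
compound 2, `COc1ccc(N2CCCNCC2)cn1`, 170 nM

Two compounds have numbers in an assay on HEK293 cells for displacement of a labelled ligand from Neuronal acetylcholine receptor; alpha4/beta2 (Homo sapiens); a lower number here means a stronger inhibitor, a higher number a weaker inhibitor. Compound 1, `COc1cc(N2CCCNCC2)cnc1Cl`, gives 0.676 nM in this assay. Compound 2, `COc1ccc(N2CCCNCC2)cn1`, gives 170 nM and so stands at the higher of the two values, far from compound 1 by a margin well beyond the scatter. Going by the values given here, no single-point step between these two is defined, as they differ in more than one place.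

Compound 3, `CCSc1ccc(N2CCCNCC2)cn1`, is not yet measured. It differs from compound 2 by one change: ethylsulfanyl in place of methoxy on an aromatic carbon. Among the compounds with values here, no pair among the measured compounds shows what such a swap does, so there is no step to lean on, only the value of compound 2 as a starting point. The expected step from compound 2 to compound 3 in this assay is therefore a 1.3-fold lower number from compound 2 to compound 3 (0.12 log units; within the scatter), likely no larger than the scatter in either direction. For compound 3 the estimated value in this assay is 130 nM, within a range from 25 nM to 700 nM.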

Compound 3, half-maximal inhibitory concentration: 170 nM
Estimate against measurement, compound 3: 1.3-fold (0.12 log units) below; the range from low to high includes it.
By their numbers in this assay, from the lowest: compound 1; then compounds 2 and 3 (each within the scatter of the next).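

In this assay, ethylsulfanyl in place of methoxy on an aromatic carbon, next to the ring nitrogen and para to a group of 7 heavy atoms, gives no change at the digits printed from compound 2 to compound 3 (within the scatter). Going by these compounds alone, this is the first reading of any swap at this position: a group of 3 heavy atoms carrying sulfur takes the place of one of 2 heavy atoms carrying oxygen, each with 1 hydrogen-bond acceptor, and the two compounds cannot be told apart in this measurement. Nothing available speaks to the reason for this outcome.

This single pair does not show how far the position accepts other replacements, such as a longer chain like butylsulfanyl, an amine or a carboxylic acid, or whether any of them would separate from compound 2 by more than the scatter. As far as these compounds go, whether ethylsulfanyl in place of methoxy would have the same outcome on the core of compound 1, which gives 0.676 nM, also stays open.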